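A few compounds are considered here, and "the series" means these few. Any claim that something is new, unique, unknown or untested is made for them only; others in the source may bear on it.

In a functional assay on SK-BR-3 cells (Homo sapiens) for cytotoxicity, read by sulforhodamine B assay, with a stated time of 3 days (a higher number here means that more compound is needed for the effect, a lower number that less compound is needed), compound 1 `CCOCc1c(C)coc1-c1ccc2c(c1OC)CCCC2(C)C` gives 19.8 uM and compound 2 `Cc1coc(-c2ccc3c(c2O)CCCC3(C)C)c1C(=O)O` gives 0.7 uM as the lower of the two numbers, a gap well beyond the usual scatter. Compound 3 `COc1c(-c2occ(C)c2C(=O)O)ccc2c1CCCC2(C)C` differs from compound 2 by methyl in place of hydrogen on an oxygen on an aromatic ring in one place: methyl in place of hydrogen on an oxygen on an aromatic ring, that is, hydroxy to methoxy. Going by the values given here, no measured pair shows this change alone. Compound 1 also carries methoxy, gives 19.8 uM and differs elsewhere too, so a moderate rise in the number, beyond the scatter, is expected. The estimated move a 4.3-fold higher number from compound 2 to compound 3 (0.63 log units; beyond the scatter) is only a rough guess. For compound 3 the expected value is 3 uM with a range from 0.8 uM to 12 uM around it.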

Compound 3, concentration for half-maximal effect: 25.5 uM
The estimate for compound 3 lay 8.5-fold (0.93 log units) below the measured number, outside the stated range (above it).
By their numbers in this assay, from the lowest: compound 2; then compounds 1 and 3 (each within the scatter of the next).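

Changing hydroxy to methoxy on the aromatic ring, with nothing else altered, gives a 36-fold higher number from compound 2 to compound 3 (1.56 log units; beyond the scatter) in this assay, so the free hydroxy matters greatly in this series. With methoxy present, carboxy in place of ethoxymethyl gives a 1.3-fold higher number from compound 1 to compound 3 (0.11 log units; within the scatter) and makes no clear difference, unlike the large hydroxy to methoxy step. No supporting measurement is available to explain why the hydroxy to methoxy step is so large. From the compounds shown here alone, it remains open whether a longer chain on that oxygen would behave like methoxy. Also open, going by these compounds, is whether an amine in place of carboxy would matter once the hydroxy is present.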